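The source may hold more compounds than are shown below. What is called first, only, known or untested is meant among the compounds shown, and "the series" means these compounds.

Measured so far in a functional assay on G-361 cells (Homo sapiens) for antiproliferative activity, with a stated time of 72 h; on this read-out lower numbers stand for stronger inhibition and higher numbers for weaker inhibition:
compound 1 `OC[C@H]1O[C@@H](n2cnc3c(NCc4ccccc4F)ncnc32)[C@H](O)[C@@H]1O`: "not determined" (no result reported)
compound 2 `OC[C@H]1O[C@@H](n2cnc3c(NCc4cccc(F)c4)ncnc32)[C@H](O)[C@@H]1O`: > 166000 nM
compound 3 `OC[C@H]1O[C@@H](n2cnc3c(NCc4ccccc4Cl)ncnc32)[C@H](O)[C@@H]1O`: "not determined" (no result reported)

The series offers very little to anchor on. Compound 3 has no single number, and its entry reads "not determined" (no result reported). Compound 1 is in the same position, with "not determined" (no result reported). Among the measured compounds shown here, the only other reading is for compound 2, and > 166000 nM is a limit of the assay, not a number. For the measured compounds named here, this gives the limit of > 166000 nM in this assay, at which 1 of the 3 values shown sits, as the whole of the quantitative evidence, and no step between two measured compounds is available.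

Next in line is compound 4 `OC[C@H]1O[C@@H](n2cnc3c(NCc4ccccc4Br)ncnc32)[C@H](O)[C@@H]1O`. The change is bromo in place of chloro on an aromatic carbon, in words bromo in place of chloro on an aromatic carbon, ortho to a large group, or 2-chlorobenzyl to 2-bromobenzyl.

Going by the values given here, with no measured step to scale from, no shift beyond the usual scatter is expected from this exchange, in either direction. Among the compounds with values here, the expectation for compound 4 therefore leans on the one reading, the limit of compound 2 with > 166000 nM, and a weak result or another limit is the likely outcome. The estimated value for compound 4 is 90000 nM, with an expected range of 15000 nM to 166000 nM.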

Compound 4, half-maximal inhibitory concentration: > 166000 nM
Compound 4 was reported as a limit; the forecaster's own chance of this, stated with the estimate: 60%; middle value at least 1.8-fold (0.26 log units) away from the limit.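

In this assay compound 4 gives > 166000 nM, which is a limit of the assay and not a number. No new step can be read between compound 2 and compound 4, as both entries are limits. The compounds shown leave open whether any of these substituted benzyl groups gives a single number in this assay.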